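A few compounds are considered here, and "the series" means these few. Any claim that something is new, unique, unknown or untested is made for them only; others in the source may bear on it.

Measured so far:
- compound 1, `CCCc1cc(N)c2cc(NC(=O)c3ccc(-c4ccc(Cl)cc4)cc3)ccc2n1`: 0.7 nM
- compound 2, `CCCc1cc(OC)c2cc(NC(=O)/C=C/c3ccc(C(F)(F)F)cc3)ccc2n1`: 26 nM
- compound 3, `CCCc1cc(N)c2cc(NC(=O)/C=C/c3ccc(O)cc3)ccc2n1`: 1100 nM

In an assay on isolated protein for displacement of a labelled ligand from melanin-concentrating hormone receptor 1 (Homo sapiens) (on this read-out higher numbers stand for weaker inhibition and lower numbers for stronger inhibition), compound 3 gives 1100 nM, the highest of the three numbers. The nearest is compound 2 with 26 nM, a lower number by a margin well beyond the scatter, and the furthest is compound 1 with 0.7 nM, lower still by a very wide margin. Compound 3 therefore stands as the weakest inhibitor among the three measured compounds.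

The next compound to be measured is compound 4, `CCCc1cc(N)c2cc(NC(=O)/C=C/c3ccc(F)cc3)ccc2n1`. It differs from compound 3 in one place only: fluoro in place of hydroxy on an aromatic carbon. Among the measured compounds shown here, no pair of measured compounds differs in just one place, so there is no single step from which to read the size of this change directly; the expectation rests on the spread of the three numbers and on the change itself.

Compound 4 is expected to land well below compound 3 in this assay, because compound 3 gives 1100 nM while the two compounds without a hydroxy group give far lower numbers. The step of an 18-fold lower number from compound 3 to compound 4 (1.26 log units; beyond the scatter) is expected to be large and downward, beyond the scatter. The estimate for compound 4 is 60 nM, with a range from 10 nM to 400 nM.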

Compound 4, half-maximal inhibitory concentration: 130 nM
For compound 4 the middle estimate is 2.2-fold (0.34 log units) below the measured one, within the range that was stated.
By their numbers in this assay, from the lowest: compound 1; then compound 2; then compound 4; then compound 3.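

Among the compounds shown here, compound 3 and compound 4 form the first pair here that differs in one place only, so the effect of a change at this position can now be read directly. Fluoro in place of hydroxy on an aromatic carbon, para to a large group, brings an 8.5-fold lower number from compound 3 to compound 4 (0.93 log units; beyond the scatter) in this assay and thus moves the read-out towards stronger inhibition by more than the scatter. The position therefore responds to the exchange of a single heavy atom, here from a group counted with one hydrogen-bond donor and one acceptor to a group counted with neither, although nothing at hand explains the step or shows which of these differences, if any, matters.

The pair has only these two end points, so it cannot show whether hydroxy lowers inhibition or fluoro raises it, and a phenyl ring with plain hydrogen at this position, or one carrying chloro, methoxy or an amine, would be needed to separate the two readings. It also leaves open whether the same exchange would give a step of similar size with a different group on the other side of the amide.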